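The source may hold more compounds than are shown below. What is called first, only, known or untested is meant among the compounds shown, and "the series" means these compounds.

Measured so far in a functional assay on DLD-1 cells (Homo sapiens) for antiproliferative activity, read by CellTiter-Glo, with a stated time of 72 h; a lower number here means a stronger inhibitor, a higher number a weaker inhibitor: compound 1 `CC1CCN(C2CCN(S(=O)(=O)c3ccc(C#N)cc3)CC2)CC1` gives 2800 nM; compound 2 `Cc1cccc(S(=O)(=O)N2CCC(N3CCC(C)CC3)CC2)c1` gives 25 nM. Compound 3 `CC1CCN(C2CCN(S(=O)(=O)c3nccn3C)CC2)CC1` reaches only a limit of this assay, > 5000 nM.

Among the two plain numbers compound 2 stands lowest, with a 110-fold lower number from compound 1 to compound 2 (2.05 log units; beyond the scatter). Compound 4 `Cc1ccc(-c2cccc(S(=O)(=O)N3CCC(N4CCC(C)CC4)CC3)c2)cc1` differs from compound 2 by 4-methylphenyl in place of methyl on an aromatic carbon. The measured steps each swap the whole ring on the sulfonyl sulfur and were large: a 110-fold lower number from compound 1 to compound 2 (2.05 log units; beyond the scatter), an at least 200-fold higher number from compound 2 to compound 3 (2.30 log units; beyond the scatter), and an at least 1.7-fold higher number from compound 1 to compound 3 (0.25 log units; that floor lies within the scatter) against the limit (the limit of > 5000 nM in this assay, at which 1 of the 3 values shown sits). None of them enlarges a group on a ring that stays, so they bear on this step only loosely. A modest shift toward a higher number is expected for compound 4, within or near the scatter: a 2.4-fold higher number from compound 2 to compound 4 (0.38 log units; beyond the scatter). Compound 4 is estimated at 60 nM, with a range from 12 nM to 400 nM.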

Compound 4, half-maximal inhibitory concentration: 11 nM
The estimate for compound 4 lay 5.5-fold (0.74 log units) above the measured number; the whole stated range lies above it.
By their numbers in this assay, from the lowest: compound 4; then compound 2; then compound 1. At a limit, above all of these: compound 3.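

Unlike the earlier steps, which swapped the whole ring on the sulfonyl sulfur, this one keeps that ring and enlarges a group on it. In this assay, an aromatic carbon that carries methyl also accepts the far larger 4-methylphenyl, with a 2.3-fold lower number from compound 2 to compound 4 (0.36 log units; beyond the scatter). Nothing in the data shown accounts for this gain.

Open, on these data alone, is whether the methyl of the added ring matters, as a plain phenyl would show. Also open, as far as these compounds go, is how a pyridine ring, or an added ring bearing an amine or a carboxylic acid, would read here.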